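Taking the Acetyl Off: One Measured Step, One Expected

A few compounds are considered here, and "the series" means these few. Any claim that something is new, unique, unknown or untested is made for them only; others in the source may bear on it.

Measured compounds:
compound 1, `CC(=O)Nc1nc(OCc2ccccc2)c2ncn(C3CC(O)C(O)O3)c2n1`, in a functional assay on M4Beu cells for cytotoxicity against M4Beu cell line (Homo sapiens), in the presence of a further agent that is not named here (on this read-out lower numbers stand for an effect already at smaller amounts and higher numbers for an effect only at larger amounts of compound), gives 165 uM
compound 2, `Nc1nc(OCc2ccccc2)c2ncn(C3CC(O)C(O)O3)c2n1`, gives 6 uM
compound 3, `CC(=O)Nc1nc(OCc2ccc(I)cc2)c2ncn(C3CC(O)C(O)O3)c2n1`, gives 269 uM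

From compound 1 to compound 2 the change is hydrogen in place of acetyl on a nitrogen on an aromatic ring; it brought a 28-fold lower number from compound 1 to compound 2 (1.44 log units; beyond the scatter). Compound 3 differs from compound 1 by iodo in place of hydrogen on an aromatic carbon, and that gave a 1.6-fold higher number from compound 1 to compound 3 (0.21 log units; within the scatter). Compound 4, `Nc1nc(OCc2ccc(I)cc2)c2ncn(C3CC(O)C(O)O3)c2n1`, has not been measured. It stands to compound 3 as compound 2 stands to compound 1: the change is hydrogen in place of acetyl on a nitrogen on an aromatic ring, at the same kind of place as before, and this change occurs twice among these four compounds. Compound 4 is expected to show a 27-fold lower number from compound 3 to compound 4 (1.43 log units; beyond the scatter) because a 28-fold lower number from compound 1 to compound 2 (1.44 log units; beyond the scatter) was seen for the identical change on the core of compound 1. Compound 4 is therefore estimated at 10 uM, between 4 uM and 25 uM.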

Compound 4, concentration for half-maximal effect: 4 uM
Beside the measured number, compound 4's estimate is 2.5-fold (0.40 log units) above it, and the stated range covers the measured number.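

In this assay, hydrogen in place of acetyl gave a 67-fold lower number from compound 3 to compound 4 (1.83 log units; beyond the scatter), and this large step agrees with the earlier one on the core of compound 1: (the same change on two cores in this assay, a 28-fold lower number (1.44 log units; beyond the scatter) from compound 1 to compound 2 and a 67-fold lower number (1.83 log units; beyond the scatter) from compound 3 to compound 4, 2.4-fold (0.39 log units) apart, within the scatter of two such steps). With iodo in place of hydrogen, the amino pair also stays within the scatter (a 1.5-fold lower number from compound 2 to compound 4 (0.18 log units; within the scatter)), matching the acetamido pair: (the same change on two cores in this assay, a 1.6-fold higher number (0.21 log units; within the scatter) from compound 1 to compound 3 and a 1.5-fold lower number (0.18 log units; within the scatter) from compound 2 to compound 4, 2.4-fold (0.39 log units) apart, within the scatter of two such steps). This shows that both changes carried across the two cores shown, but these cores differ only by the iodo and acetyl groups, so it does not show that either change would carry to a core differing elsewhere, nor why the acetyl loss has this effect.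

The compounds shown leave open how a methylamino group or a longer acyl chain would compare on the same nitrogen. They also leave open whether chloro or bromo would behave as iodo does.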